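This account rests on a few compounds, and the source may have more. Where it says the series, first, only, none or still open, it means among the compounds named here.

Measured in a functional assay on the whole organism (Tail, strain ICR) with Mus musculus as the target, in the tail flick test, with a stated time of 120 min, at a dose of 25 umol/kg by the oral route; on this read-out higher numbers stand for a stronger effect at the one dose given and lower numbers for a weaker effect:
compound 1 `O=C(O)[C@@H]1CCCN1C(=O)CN(c1nc(Cl)nc2[nH]cnc12)C1CC1` gives 23.6%;
compound 2 `C[C@@H](O)[C@H](NC(=O)CN(c1nc(Cl)nc2[nH]cnc12)C1CC1)C(=O)OCc1ccccc1` gives 30.7%;
compound 3 `O=C(CN(c1ncnc2c1ncn2C1CCCCO1)C1CC1)N[C@@H](CO)C(=O)OCc1ccccc1` gives 29.2%.

Compound 3 sits among the other two in this assay: its gap to compound 2 and its gap to compound 1 both lie within the usual scatter of repeated measurements, so the three numbers cannot be told apart with confidence. The three compounds also differ from one another in several places at once, so no single structural change can be paired with a measured step.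

Compound 4 `CSCC[C@H](NC(=O)CN(c1ncnc2c1ncn2C1CCCCO1)C1CC1)C(=O)OCc1ccccc1` is not yet measured. It differs from compound 3 in one place: (methylsulfanyl)methyl in place of hydroxy on a saturated chain carbon, two bonds along the chain from an amide-type nitrogen and a carbonyl carbon. No measured pair shows what this exchange does, so the expectation rests only on the numbers shown, all of which sit close together. Compound 4 is therefore expected to stay near compound 3, with a step from compound 3 to compound 4 of a number 0.8 percentage points higher from compound 3 to compound 4 (within the scatter), which is expected to lie within the scatter. The estimate for compound 4 in this assay is 30%, with a range from 15% to 45%.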

Compound 4, a percentage reported as activity, at one dose (the size of the read-out at that dose, not a potency): 28.7%
Estimate against measurement, compound 4: 1.3 percentage points above, and the stated range covers the measured number.
By their numbers in this assay, from the lowest: compounds 1, 4, 3 and 2 (each within the scatter of the next).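

In this assay, going by these compounds alone, the exchange of hydroxy for (methylsulfanyl)methyl on a saturated chain carbon, two bonds along the chain from an amide-type nitrogen and a carbonyl carbon, yields the first step that can be read at this position. A move of a number 0.5 percentage points lower from compound 3 to compound 4 (within the scatter) means that, at this one dose and time, the read-out does not separate the two groups. Nothing measured here offers an explanation for this result.

As far as these compounds go, whether an amine, a carboxylic acid or a longer chain at this position would give a step beyond the scatter remains open. Also open, from the compounds shown here alone, is whether the same exchange would give a similar step on the core of compound 1, or at another dose or time.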